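Replacing the bromo group of compound 1 with hydrogen

The source may report more compounds than this note shows. Statements on the series, on what has been measured and on what is new or still open speak of the compounds shown alone.

Measured values in a functional assay on PANC-1 cells (Homo sapiens) for antiproliferative activity, read by fluorescence and resazurin assay, with a stated time of 48 h (a higher number here means a weaker inhibitor, a lower number a stronger inhibitor), follow
Compound 1 `CCOc1ccc(NC(=O)c2cc3cc(Br)ccc3oc2=O)cc1` gives 16800 nM
Compound 2 `CCOc1ccc2nc(Cl)c(/C=N/NC(=O)c3cc4ccccc4oc3=O)cc2c1` gives 29900 nM

The values of compound 1 and compound 2 lie within the usual scatter of each other, so neither ranks ahead on these numbers. Compound 3 `CCOc1ccc(NC(=O)c2cc3ccccc3oc2=O)cc1` keeps the core of compound 1 with a single change hydrogen in place of bromo on an aromatic carbon that puts hydrogen in place of bromo on an aromatic carbon. Going by the values given here, no two measured compounds differ in only one place, so the data offer no measured step to go by. A modest step toward a higher number is expected in this assay and it may not pass beyond the scatter. The estimate amounts to a 1.7-fold higher number from compound 1 to compound 3 (0.22 log units; within the scatter) and remains an expectation only. For compound 3 the estimated value is 28000 nM (expected range 11000 nM to 75000 nM).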

Compound 3, half-maximal inhibitory concentration: 13400 nM
For compound 3 the middle estimate is 2.1-fold (0.32 log units) above the measured one; the measured number falls inside the stated range.
By their numbers in this assay, from the lowest: compounds 3, 1 and 2 (each within the scatter of the next, the first and the last beyond it).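

In this assay, hydrogen in place of bromo on this aromatic carbon gives a 1.3-fold lower number from compound 1 to compound 3 (0.10 log units; within the scatter), a step within the scatter. Going by these compounds alone, this is the first direct reading of a single change, and on these numbers bromo and hydrogen at this place cannot be told apart, so the value of compound 1 does not depend measurably on its bromine atom. No measurement at hand bears on why the exchange leaves so little trace.

From the compounds shown here alone, whether another group at this place, such as an amine, a methoxy group or a carboxylic acid, would shift the number beyond the scatter remains open. With only bromo and hydrogen to compare here, the compounds shown also leave open how much of a change this place can take in either direction.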